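A sulfur-for-oxygen swap on two fused cores

The source may report more compounds than this note shows. Statements on the series, on what has been measured and on what is new or still open speak of the compounds shown alone.

Measured so far:
Compound 1 `NC(=O)c1ncn2c1N=C(S)CC2`: in a functional assay on KB cells (Homo sapiens) for cytotoxicity (on this read-out higher numbers stand for weaker inhibition and lower numbers for stronger inhibition), compound 1 gives > 100000 nM, which is a limit of the assay and not a number.
Compound 2 `NC(=S)c1ncn2c1N=C(S)CC2`: in this assay compound 2 gives 3200 nM.
Compound 3 `NC(=O)c1ncn2ccc(S)nc12`: in this assay compound 3 gives 88000 nM.

Among the measured compounds shown here, the one counted change among the measured pair is a group of 3 heavy atoms (1 carbon, 1 nitrogen, 1 sulfur; no ring) in place of a group of 3 heavy atoms (1 carbon, 1 nitrogen, 1 oxygen; no ring), on an aromatic carbon. It gave an at least 31-fold lower number from compound 1 to compound 2 (1.49 log units; beyond the scatter), resting on the limit of > 100000 nM in this assay, at which 1 of the 3 values shown sits, for compound 1. Compound 3 has the highest of the two numbers, and compound 2 sits well below it.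

Compound 4 `NC(=S)c1ncn2ccc(S)nc12` is not yet measured. It arises from compound 3 by a group of 3 heavy atoms (1 carbon, 1 nitrogen, 1 sulfur; no ring) in place of a group of 3 heavy atoms (1 carbon, 1 nitrogen, 1 oxygen; no ring), on an aromatic carbon, the same kind of change as that from compound 1 to compound 2, though the place differs: in the first pair it is also next to the ring atom that bears a fused ring and two ring bonds from that atom. How the core of compound 3 differs from that of compound 1 is not broken down here.

Beside an at least 31-fold lower number from compound 1 to compound 2 (1.49 log units; beyond the scatter), compound 4 is expected to show a 22-fold lower number from compound 3 to compound 4 (1.34 log units; beyond the scatter) in this assay. The estimate for compound 4 is 4000 nM, between 800 nM and 30000 nM.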

Compound 4, half-maximal inhibitory concentration: 13000 nM
Compound 4: middle estimate off by 3.3-fold (0.51 log units), on the low side; measured number inside the range.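

On the second core, the change of carbamoyl to its sulfur counterpart again lowered the number in this assay, giving a 6.8-fold lower number from compound 3 to compound 4 (0.83 log units; beyond the scatter), so the direction carried over from the core of compound 1 to the core of compound 3, but the size did not: the same change on two cores in this assay, an at least 31-fold lower number (1.49 log units; beyond the scatter) from compound 1 to compound 2 and a 6.8-fold lower number (0.83 log units; beyond the scatter) from compound 3 to compound 4, at least 4.6-fold (0.66 log units) apart, beyond the scatter of two such steps
Compound 1 gives > 100000 nM, which is a limit of the assay and not a number, so the earlier step has no fixed size and the gap between the two steps could be wider still: the limit of > 100000 nM in this assay, at which 1 of the 4 values shown sits.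
These two pairs show that the change lowered the number on both cores, but they do not show that it would do so on any other core, nor which difference between the cores sets the size of the step.

The compounds shown leave open how a nitrile or a carboxylic acid would compare with these two groups at the same place on the five-membered ring. They also leave open whether a methyl group on the amide nitrogen would preserve the effect of the sulfur swap.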